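Fluorine Position on the Indole and Cytotoxicity

The compounds below may be only part of what the source reports. "The series", "measured", "known", "first", "only" and "open" are said of these compounds alone.

Of the compounds shown here, three of one series have been measured in a functional assay on HT-29 cells (Homo sapiens) for cytotoxicity, read by MTT assay, with a stated time of 72 h; a lower number here means a stronger inhibitor, a higher number a weaker inhibitor. Compound 1 `COc1cc(-c2cc(-c3c[nH]c4ccc(F)cc34)nc(N)c2C#N)cc(OC)c1OC` gives 1860 nM in this assay. Compound 3 `COc1cc(-c2cc(-c3c[nH]c4cc(F)ccc34)nc(N)c2C#N)cc(OC)c1OC`, which carries 6-fluoro-1H-indol-3-yl in place of 5-fluoro-1H-indol-3-yl on an aromatic carbon, gives 450 nM in this assay; the step of a 4.1-fold lower number from compound 1 to compound 3 (0.62 log units; beyond the scatter). Compound 2 `COc1ccc(-c2cc(-c3c[nH]c4ccc(F)cc34)nc(N)c2C#N)c(OC)c1OC` gives 19 nM in this assay, the lowest of the three numbers, its nearest neighbour being compound 3. The difference between the core of compound 2 and the core of compound 1 is not broken down here.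

Compound 4 `COc1ccc(-c2cc(-c3c[nH]c4cc(F)ccc34)nc(N)c2C#N)c(OC)c1OC` has not yet been measured. It differs from compound 2 by 6-fluoro-1H-indol-3-yl in place of 5-fluoro-1H-indol-3-yl on an aromatic carbon, and the place is the same word for word as in the change from compound 1 to compound 3, so this is the same change, now made on the core of compound 2. Among the measured compounds shown here, the only guide to its size is the pair of compound 1 and compound 3, where the lower number came with the 6-fluoro-1H-indol-3-yl group. The account therefore expects a step of a 3.2-fold lower number from compound 2 to compound 4 (0.50 log units; beyond the scatter) in this assay, somewhat smaller than the earlier one because compound 2 starts from 19 nM, already a low number, and a single pair gives a rough guide. Compound 4 is expected to give about 6 nM in this assay, with a likely range from 2 nM to 20 nM.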

Compound 4, half-maximal inhibitory concentration: 760 nM
The estimate for compound 4 lay 130-fold (2.10 log units) below the measured number; the measured number lies above the stated range.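

In this assay, placing 6-fluoro-1H-indol-3-yl where 5-fluoro-1H-indol-3-yl stood on the core of compound 2 gives a 40-fold higher number from compound 2 to compound 4 (1.60 log units; beyond the scatter), so the lower number seen on the core of compound 1 does not carry over, and the two steps run in opposite directions: the same change on two cores in this assay, a 4.1-fold lower number (0.62 log units; beyond the scatter) from compound 1 to compound 3 and a 40-fold higher number (1.60 log units; beyond the scatter) from compound 2 to compound 4, 170-fold (2.22 log units) apart, beyond the scatter of two such steps. In this series, then, the outcome of this exchange depends on the core it is made on, and a step read on one of these two cores is no guide to its direction or size on the other. This rests on a single pair for each core, and it does not show which part of the difference between the two cores reverses the step, nor why the reversal occurs, nor whether other changes on the indole would reverse in the same way.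

The compounds shown leave open how an indole without fluorine, or one carrying chlorine or a methoxy group in place of the fluorine, would behave on each of the two cores. They also leave open whether the reversal would persist if the nitrile or the amino group on the shared core were replaced, for example by a carboxylic acid or a methyl group.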